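From compound 2 to compound 4: benzamido for methoxy

This account rests on a few compounds, and the source may have more. Where it says the series, first, only, none or still open, it means among the compounds named here.

Three compounds with a shared core have been examined so far: compound 1 `Cc1ccc(CN2CCC=C(CCC(=O)NO)C2=O)cc1`, compound 2 `COc1ccc(CN2CCC=C(CCC(=O)NO)C2=O)cc1` and compound 3 `O=C(CCC1=CCCN(Cc2ccc3ccccc3c2)C1=O)NO`. In a functional assay on PC-3 cells (Homo sapiens) for inhibition, read by sulforhodamine B assay (on this read-out lower numbers stand for stronger inhibition of growth and higher numbers for weaker inhibition of growth), compound 1 gives 8100 nM and compound 2 gives 7080 nM. For compound 3 the result is "not determined" (no result reported), which leaves only these two numbers. Methoxy in place of methyl on an aromatic carbon gives a 1.1-fold lower number from compound 1 to compound 2 (0.06 log units; within the scatter), a step within the scatter, so the two numbers cannot be ranked.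

The next structure is compound 4 `O=C(CCC1=CCCN(Cc2ccc(NC(=O)c3ccccc3)cc2)C1=O)NO`, which carries benzamido in place of methoxy on an aromatic carbon, para to a large group (benzamido in place of methoxy on an aromatic carbon). Within the data shown here, the entering group brings one six-membered aromatic ring of carbon only, a far larger change than the one measured step. Among the measured compounds shown here, that step, a 1.1-fold lower number from compound 1 to compound 2 (0.06 log units; within the scatter), is the only measured guide, and it bears on this change only weakly. Compound 3 adds no number, so the data support no direction.

The working expectation therefore starts from compound 2 at 7080 nM in this assay, with no change beyond the scatter. The expected step is a 1.4-fold lower number from compound 2 to compound 4 (0.15 log units; within the scatter). For compound 4 the estimate is 5000 nM, with an expected range from 1500 nM to 15000 nM.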

Compound 4, concentration for 50% growth inhibition: > 10000 nM
Compound 4 was reported as a limit (the forecaster's own chance of this, stated with the estimate: 10%); middle value at least 2.0-fold (0.30 log units) away from the limit.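

In this assay compound 4 is reported only as a limit, > 10000 nM. Read as floors, the steps are an at least 1.4-fold higher number from compound 2 to compound 4 (0.14 log units; that floor lies within the scatter) and an at least 1.2-fold higher number from compound 1 to compound 4 (0.09 log units; that floor lies within the scatter), so benzamido on this aromatic carbon, para to a large group, gives no lower number than methoxy or methyl, although the floors alone do not separate compound 4 from either compound. Among these compounds, the earlier pair compared only two small groups, whereas this result extends the position to a group with one six-membered aromatic ring and an amide hydrogen, and the size of the step cannot be read beyond the floors because the result sits at a limit: the limit of > 10000 nM in this assay, at which 1 of the 4 values shown sits.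

Going by these compounds, it remains open whether an amine or a carboxylic acid in place of benzamido at this position would move the number beyond the scatter from the methoxy and methyl compounds, and in which direction. On these data alone, the true size of the step to benzamido also stays open, and with it whether compound 4 differs from compound 1 and compound 2 at all.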